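Replacing a fluoro-methoxybenzyl with a hydroxy-methoxybenzyl

The source may report more compounds than this note shows. Statements on the series, on what has been measured and on what is new or still open speak of the compounds shown alone.

Measured compounds:
compound 1, `COc1cccc(CNCCCNc2ccnc3cc(Oc4cccc(N(C)C)c4)ccc23)c1O`: 14500 nM
compound 2, `COc1cccc(CNCCCNc2ccnc3cc(CC(C)C)ccc23)c1O`: 4200 nM
compound 3, `COc1ccc(F)cc1CNCCCNc1ccnc2cc(-c3cccc4ccccc34)ccc12`: 32000 nM

In a physicochemical assay for solubility, with a stated time of 18 h, at pH 7.4 (a lower number here means a less soluble compound, a higher number a more soluble compound), compound 3 gives the highest of the three numbers, with compound 1 closest and compound 2 furthest from it. Compound 4, `COc1cccc(CNCCCNc2ccnc3cc(-c4cccc5ccccc45)ccc23)c1O`, differs from compound 3 in one place: 2-hydroxy-3-methoxyphenyl in place of 5-fluoro-2-methoxyphenyl on a saturated chain carbon bound to an amine nitrogen. Within the data shown here, the only measured step, a 3.5-fold lower number from compound 1 to compound 2 (0.54 log units; beyond the scatter), changes a different part of the molecule and says nothing directly about the benzyl group. Among the measured compounds shown here, no measured pair isolates this change, so the direction is open, and a step within the scatter is the most defensible expectation. Compound 4 is therefore expected to stay close to compound 3, a 1.5-fold lower number from compound 3 to compound 4 (0.16 log units; within the scatter), with an estimated value of 22000 nM and a range from 8000 nM to 60000 nM.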

Compound 4, solubility: 32000 nM
Estimate against measurement, compound 4: 1.5-fold (0.16 log units) below; measured number inside the range.
By their numbers in this assay, from the lowest: compound 2; then compound 1; then compounds 3 and 4 (each within the scatter of the next).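

In this assay, 2-hydroxy-3-methoxyphenyl in place of 5-fluoro-2-methoxyphenyl gives no change at the digits printed from compound 3 to compound 4 (within the scatter), so with naphthalen-1-yl on the core, this exchange, which brings a hydrogen-bond donor, separates the two compounds by nothing beyond the scatter. With the 2-hydroxy-3-methoxybenzyl group held fixed, naphthalen-1-yl in place of isobutyl gives a 7.6-fold higher number from compound 2 to compound 4 (0.88 log units; beyond the scatter), and in place of 3-(dimethylamino)phenoxy it gives a 2.2-fold higher number from compound 1 to compound 4 (0.34 log units; beyond the scatter). No measurement here offers an explanation for these results. As far as these compounds go, whether the benzyl exchange reads the same with isobutyl or 3-(dimethylamino)phenoxy on the core remains open. So does the outcome for a benzyl group carrying an amine or a carboxylic acid.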